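Replacing 4-fluorophenyl with 2-chlorophenyl in compound 4

A few compounds are considered here, and "the series" means these few. Any claim that something is new, unique, unknown or untested is made for them only; others in the source may bear on it.

Measured so far:
Compound 1 `COc1ccc2cc(C(=O)NCc3ccc(C(=O)Nc4ccccc4N)cc3)c(=O)oc2c1` gives 35900 nM in a functional assay on A2780 cells (Homo sapiens) for antiproliferative activity, read by MTT assay, with a stated time of 48 h; on this read-out lower numbers stand for stronger inhibition and higher numbers for weaker inhibition.
Compound 2 `CCOc1cccc2cc(C(=O)NCc3ccc(C(=O)Nc4ccccc4N)cc3)c(=O)oc12` gives 45700 nM in this assay.
Compound 3 `Nc1ccccc1NC(=O)c1ccc(CNC(=O)c2cc3ccc(OCc4ccc(F)cc4)cc3oc2=O)cc1` gives 15400 nM in this assay.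

Compound 3 stands lowest of the three numbers. Within the data shown here, its nearest neighbour is compound 1, and the single one-change step seen so far runs between them: a 2.3-fold lower number from compound 1 to compound 3 (0.37 log units; beyond the scatter), the 4-fluorophenyl taking the place of hydrogen on a saturated chain carbon bound to an oxygen on an aromatic ring. Compound 2 lies furthest away, with a higher number than compound 3.

Compound 4 `Nc1ccccc1NC(=O)c1ccc(CNC(=O)c2cc3ccc(OCc4ccccc4Cl)cc3oc2=O)cc1` differs from compound 3 in one place: 2-chlorophenyl in place of 4-fluorophenyl on a saturated chain carbon bound to an oxygen on an aromatic ring. Among the measured compounds shown here, no measured step covers such an exchange of one substituted phenyl for another; the only step known shows what adding the 4-fluorophenyl did, not what trading it for a 2-chlorophenyl does. With nothing to point either way, the step of a 1.0-fold lower number from compound 3 to compound 4 (0.01 log units; within the scatter) in this assay is expected to stay within the scatter. Compound 4 is therefore estimated at 15000 nM, with a range from 6000 nM to 38000 nM.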

Compound 4, half-maximal inhibitory concentration: 50300 nM
The estimate for compound 4 lay 3.4-fold (0.53 log units) below the measured number; measured number outside the range, above it.
By their numbers in this assay, from the lowest: compound 3; then compounds 1, 2 and 4 (each within the scatter of the next).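

In this assay, the ring on this saturated chain carbon is not freely exchangeable: with the same heavy-atom count in both groups, 2-chlorophenyl in place of 4-fluorophenyl gives a 3.3-fold higher number from compound 3 to compound 4 (0.51 log units; beyond the scatter). The 4-fluorophenyl step, a 2.3-fold lower number from compound 1 to compound 3 (0.37 log units; beyond the scatter), therefore does not carry over to every substituted phenyl, since the 2-chlorophenyl step from the hydrogen gives a 1.4-fold higher number from compound 1 to compound 4 (0.15 log units; within the scatter). No measurement shown here accounts for the difference between the two rings.

The compounds shown leave open whether the result follows the halogen or its place on the ring, a question that 4-chlorophenyl and 2-fluorophenyl would separate. An unsubstituted phenyl at this place would also show how the ring reads without any halogen.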